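Swapping a Fluorinated Ether for a Cyclopentyl Thioether

A few compounds are considered here, and "the series" means these few. Any claim that something is new, unique, unknown or untested is made for them only; others in the source may bear on it.

Measured so far:
compound 1, `CCCCSc1nc(N)nc2c1ncn2/C=C1/CC1(CO)CO`: > 300000 nM
compound 2, `Nc1nc(OCC(F)(F)F)c2ncn(/C=C3/CC3(CO)CO)c2n1`: > 300000 nM

Of the compounds shown here, two built on a shared core have been tested in an ADME assay on HFF cells (Homo sapiens) for cytotoxicity, with a stated time of 8 days; a lower number here means that less compound is tolerated, a higher number that more compound is tolerated. For compound 1 the value of > 300000 nM is a limit of the assay, not a number. For compound 2 the value of > 300000 nM is likewise a limit. The change between them is a step that the two limits leave unreadable from compound 1 to compound 2. For the measured compounds named here, compound 2 therefore stands with no number at all, only a limit; the one other value shown sits at the same place, (the limit of > 300000 nM in this assay, at which 2 of the 2 values shown sit).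

Compound 3, `Nc1nc(SC2CCCC2)c2ncn(/C=C3/CC3(CO)CO)c2n1`, is not yet measured. (cyclopentylsulfanyl in place of 2,2,2-trifluoroethoxy on an aromatic carbon). Going by the values given here, the only measured step, a step that the two limits leave unreadable from compound 1 to compound 2, cannot be read, so it supplies no size to lean on. Given (the limit of > 300000 nM in this assay, at which 2 of the 2 values shown sit), compound 3 is expected to stay at or near the same limit. The step of a number no higher from compound 2 to compound 3 (the limit leaves the size open) is expected to be none beyond the scatter. The estimate for compound 3 in this assay is 300000 nM, with a range from 100000 nM to 1000000 nM.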

Compound 3, half-maximal cytotoxic concentration: > 300000 nM
Compound 3 ended at the assay's limit; the forecaster's own chance of this, stated with the estimate: 80%; the middle value sits exactly at the limit.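

In this assay compound 3 gives > 300000 nM, which is a limit of the assay and not a number. No step among compound 1, compound 2 and compound 3 can be read, because all three share one limit: the limit of > 300000 nM in this assay, at which 3 of the 3 values shown sit.

The compounds shown leave open whether butylsulfanyl, 2,2,2-trifluoroethoxy and cyclopentylsulfanyl differ at all in this assay, and at what concentration, if any, each compound becomes toxic to the cells.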